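Amine tail change on the diarylurea series

This account rests on a few compounds, and the source may have more. Where it says the series, first, only, none or still open, it means among the compounds named here.

Compound 2 `CN(C)CCCNc1nc(-c2ccc(NC(=O)Nc3ccc(Cl)cc3)cc2)nc2c(Cl)c(Cl)sc12` gives 1530 nM in a functional assay on MKN-45 cells (Homo sapiens) for cytotoxicity, read by MTT assay, with a stated time of 72 h; a higher number here means a weaker inhibitor, a lower number a stronger inhibitor. Compound 1 `CN(C)CCCNc1nc(-c2ccc(NC(=O)Nc3ccc(F)cc3)cc2)nc2c(Cl)c(Cl)sc12` gives 1120 nM in this assay, and the step of a 1.4-fold higher number from compound 1 to compound 2 (0.14 log units; within the scatter) is within the scatter, so the two numbers are not separable. Compound 3 `CCN(CC)CCNc1nc(-c2ccc(NC(=O)Nc3ccc(Cl)cc3)cc2)nc2c(Cl)c(Cl)sc12` differs from compound 2 by diethylamino in place of (dimethylamino)methyl on a saturated chain carbon, two bonds along the chain from a nitrogen on an aromatic ring. Among the compounds with values here, no measured step touches this tail; the only step so far changes a halogen on an aromatic carbon, not the chain. The expected step is therefore a 1.0-fold lower number from compound 2 to compound 3 (0.01 log units; within the scatter), nothing beyond the scatter, with wide uncertainty. Compound 3 is estimated at 1500 nM, within 500 nM to 4500 nM.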

Compound 3, half-maximal inhibitory concentration: 890 nM
Compound 3: middle estimate off by 1.7-fold (0.23 log units), on the high side; the range from low to high includes it.
By their numbers in this assay, from the lowest: compounds 3, 1 and 2 (each within the scatter of the next).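

The first step read on this chain, 3-(dimethylamino)propyl to 2-(diethylamino)ethyl, gives a 1.7-fold lower number from compound 2 to compound 3 (0.24 log units; within the scatter) in this assay. The two numbers cannot be separated, so this tail swap, which alters the chain and the amine substituents together, shows no effect beyond the scatter. Nothing available bears on the reason for this result.

As far as these compounds go, whether a cyclic amine such as morpholine or piperidine, or a longer chain, would give a step beyond the scatter stays open. Also open, from the compounds shown here alone, is how 2-(diethylamino)ethyl reads with fluoro in place of chloro on the aromatic carbon.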